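The source may report more compounds than this note shows. Statements on the series, on what has been measured and on what is new or still open speak of the compounds shown alone.

Two compounds have so far been examined in an ADME assay on PBMC cells (Homo sapiens) for cytotoxicity, read by MTT assay, with a stated time of 72 h, in the presence of a further agent that is not named here; on this read-out lower numbers stand for stronger inhibition and higher numbers for weaker inhibition. Compound 1, `Fc1ccc(Nc2ccc3ccccc3n2)cc1`, gives 65000 nM in this assay. Compound 2, `CCc1ccc(Nc2nc3ccccc3cc2-c2ccccc2)cc1`, gives 66000 nM in this assay. Compound 2 thus shows the higher of the two numbers, yet its gap to compound 1 lies within the scatter of repeated measurements, so the two compounds cannot be placed in any order. The step now followed leads from compound 2 to compound 3, `COc1cccc(Nc2nc3ccccc3cc2-c2ccccc2)c1`, which has not yet been measured. The change is 3-methoxyphenyl in place of 4-ethylphenyl on a nitrogen on an aromatic ring. Going by the values given here, no step between measured compounds is available for comparison; both measured values sit close together, and nothing in these data points to a move beyond the scatter in this assay in either direction. Compound 3 is therefore expected to give 60000 nM, with a range from 30000 nM to 120000 nM. The expected step is a 1.1-fold lower number from compound 2 to compound 3 (0.04 log units; within the scatter), essentially no change beyond the scatter.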

Compound 3, half-maximal inhibitory concentration: 81000 nM
Compound 3: middle estimate off by 1.4-fold (0.13 log units), on the low side; measured number inside the range.
By their numbers in this assay, from the lowest: compounds 1, 2 and 3 (each within the scatter of the next).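

In this assay, putting 3-methoxyphenyl in place of 4-ethylphenyl on the nitrogen gives a 1.2-fold higher number from compound 2 to compound 3 (0.09 log units; within the scatter) and so leaves compound 2 and compound 3 indistinguishable. This first measured step at this place shows that an exchange of the whole group, keeping the count of heavy atoms and adding one hydrogen-bond acceptor, does not carry the number beyond the scatter. No measurement is at hand that would explain this result.

The step exchanges the whole group, so it does not separate the loss of the ethyl group from the gain of the methoxy group. It also leaves open whether a more different group on this ring, such as an amine, a carboxylic acid or a longer chain, would move the number beyond the scatter.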